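Swapping a benzyl ester for an isobutyl ketone

A few compounds are considered here, and "the series" means these few. Any claim that something is new, unique, unknown or untested is made for them only; others in the source may bear on it.

Measured compounds:
compound 1, `CCCOC(=O)/C=C(C)/C=C/CC(C)CCCC(C)C`, 7.28
compound 2, `CC(/C=C/CC(C)CCCC(C)C)=C\C(=O)OCc1ccccc1`, 7.87
compound 3, `CCOC(=O)/C=C(C)/C=C/CC(C)CCCC(C)(C)OC(C)=O`, 5.57

These three share a long branched chain carrying a conjugated carbonyl group and differ at the end of that carbonyl. Compound 2 gives the highest number of the three in a physicochemical assay for lipophilicity; on this read-out lower numbers stand for lower lipophilicity and higher numbers for higher lipophilicity; compound 1 stands nearest, and compound 3 stands furthest, its value well below the other two.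

The step to the unmeasured compound 4, `CC(/C=C/CC(C)CCCC(C)C)=C\C(=O)CC(C)C`, is isobutyl in place of benzyloxy on a carbonyl carbon. Among the measured compounds shown here, one measured step bears on it: a number 0.59 log units higher from compound 1 to compound 2 (beyond the scatter), which shows how much a phenyl ring added to the chain on the oxygen side of the carbonyl. Compound 4 removes that ring together with the oxygen and puts a short branched chain directly on the carbonyl. Against compound 1, which has a plain three-carbon chain on that oxygen, compound 4 carries one carbon more and one oxygen fewer, so a number near compound 1 or a little above it is expected, and a downward step from compound 2 of a number 0.22 log units lower from compound 2 to compound 4 (within the scatter), within the usual scatter. Compound 4 is therefore estimated at 7.65, with a range from 7.1 to 8.2.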

Compound 4, partition coefficient: 7.22
For compound 4 the middle estimate is 0.43 log units above the measured one, within the range that was stated.
By their numbers in this assay, from the lowest: compound 3; then compounds 4 and 1 (each within the scatter of the next); then compound 2.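

In this assay, isobutyl in place of benzyloxy on a carbonyl carbon gives a number 0.65 log units lower from compound 2 to compound 4 (beyond the scatter) and the same isobutyl set against the propyl ester gives a number 0.06 log units lower from compound 1 to compound 4 (within the scatter) so the isobutyl ketone and the propyl ester cannot be told apart on this read-out. Among compounds 1, 2 and 4, benzyloxy, the only one of the three groups with a ring, is the one that stands apart, and losing the ester oxygen does not by itself separate compound 4 from compound 1. Nothing shown here accounts for these numbers.

Left open is whether the ring or the oxygen of benzyloxy matters more, which a benzyl group on the same carbonyl carbon would help to separate. From the compounds shown here alone, how an amine or a carboxylic acid at this place would read also remains open.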